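The source may hold more compounds than are shown below. What is called first, only, known or untested is meant among the compounds shown, and "the series" means these compounds.

In an ADME assay on microsomes from liver (Homo sapiens) for metabolic stability, read by LC-MS, using NADPH, with a stated time of 10 min, tested at 0.5 uM (a lower number here means that less of the compound is left, a higher number that more of the compound is left), compound 2 `CC(=O)Nc1cc(-c2ccc(OC[C@@H](N)CC(C)C)c(C)c2)ccn1` gives 91%, which lies within the usual scatter of the other two measured compounds: compound 1 `CC(=O)Nc1cc(-c2ccc(OC[C@@H](N)CC(C)C)c(F)c2)ccn1` gives 90% and compound 3 `COC(=O)Nc1cc(-c2cnc(OC[C@@](C)(N)CC(C)C)c(OC)c2)ccn1` gives 86%. Compound 4 `CC(=O)Nc1cc(-c2ccc(OC[C@@H](N)CC(C)C)c(OC(F)(F)F)c2)ccn1` is still unmeasured. It carries trifluoromethoxy in place of methyl on an aromatic carbon, ortho to a (2-amino-4-methylpentyl)oxy group (trifluoromethoxy in place of methyl on an aromatic carbon). Within the data shown here, the only measured step at this place is a number 1 percentage points higher from compound 1 to compound 2 (within the scatter), with methyl in place of fluoro, so no step beyond the scatter is expected in this assay. Among the measured compounds shown here, no measured compound carries trifluoromethoxy, which leaves this expectation uncertain. The expected step is a number 5 percentage points lower from compound 2 to compound 4 (within the scatter). Compound 4 is estimated at 86%, with an expected range from 72% to 97%.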

Compound 4, percent of the compound remaining: 91%
Compound 4: the middle estimate sits 5 percentage points below what was measured; the measured number falls inside the stated range.
By their numbers in this assay, from the lowest: compounds 3, 1, 2 and 4 (each within the scatter of the next).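

In this assay the aromatic carbon ortho to a (2-amino-4-methylpentyl)oxy group now carries a third group, the larger trifluoromethoxy, and the swap for methyl gives no change at the digits printed from compound 2 to compound 4 (within the scatter) while the swap for fluoro gives a number 1 percentage points higher from compound 1 to compound 4 (within the scatter) as the remaining pair. This read-out therefore does not separate fluoro, methyl and trifluoromethoxy at this position. Nothing available here explains this result. Still open, going by these compounds, is whether an amine, a carboxylic acid or a longer chain on this carbon would give a step beyond the scatter.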